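Thioether substituent variation on a pyrrolopyrimidine-piperidine series

A few compounds are considered here, and "the series" means these few. Any claim that something is new, unique, unknown or untested is made for them only; others in the source may bear on it.

Measured so far in a functional assay on MGC-803 cells (Homo sapiens) for inhibition, read by MTT assay, with a stated time of 72 h; on this read-out higher numbers stand for weaker inhibition and lower numbers for stronger inhibition:
compound 1 `Cc1cc(N2CC[C@@H](C)[C@@H](N(C)c3ncnc4[nH]ccc34)C2)n2nc(SCc3ccc(Cl)cc3)nc2n1`, 16000 nM
compound 2 `Cc1cc(N2CC[C@@H](C)[C@@H](N(C)c3ncnc4[nH]ccc34)C2)n2nc(SCc3nc4ccccc4[nH]3)nc2n1`, 21200 nM
compound 3 `C=CCSc1nc2nc(C)cc(N3CC[C@@H](C)[C@@H](N(C)c4ncnc5[nH]ccc45)C3)n2n1`, 32600 nM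

Compound 1 gives the lowest of the three numbers. Its nearest neighbour is compound 2, at a 1.3-fold higher number from compound 1 to compound 2 (0.12 log units; within the scatter); its furthest is compound 3, at a 2.0-fold higher number from compound 1 to compound 3 (0.31 log units; beyond the scatter). Compound 4 `Cc1cc(N2CC[C@@H](C)[C@@H](N(C)c3ncnc4[nH]ccc34)C2)n2nc(SCCCc3ccccc3)nc2n1` differs from compound 1 in one place: phenethyl in place of 4-chlorophenyl on a saturated chain carbon bound to a sulfur. All three measured steps also replace the group on a saturated chain carbon bound to a sulfur, and none moved the number by more than a modest amount, so for compound 4 a step no larger than these is expected, if anything towards a higher number. Compound 4 is therefore estimated at 21000 nM, within 9000 nM to 48000 nM, meaning an expected step of a 1.3-fold higher number from compound 1 to compound 4 (0.12 log units; within the scatter).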

Compound 4, half-maximal inhibitory concentration: > 100000 nM
Compound 4: only a limit was reported (the forecaster's own chance of this, stated with the estimate: 5%); middle value at least 4.7-fold (0.67 log units) away from the limit.
By their numbers in this assay, from the lowest: compounds 1, 2 and 3 (each within the scatter of the next, the first and the last beyond it). At a limit, above all of these: compound 4.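

The group on a saturated chain carbon bound to a sulfur is less forgiving than compounds 1, 2 and 3 suggested: in this assay, phenethyl gives an at least 6.2-fold higher number from compound 1 to compound 4 (0.79 log units; beyond the scatter), an at least 4.7-fold higher number from compound 2 to compound 4 (0.67 log units; beyond the scatter) and an at least 3.0-fold higher number from compound 3 to compound 4 (0.48 log units; beyond the scatter). Compound 4 reached only a limit, so these steps have no upper bound: the limit of > 100000 nM in this assay, at which 1 of the 4 values shown sits. The change from 4-chlorobenzyl to 3-phenylpropyl alters the chain and removes the chlorine together.

Which of the two goes with the higher number stays open. Benzyl and 3-(4-chlorophenyl)propyl on the sulfur would separate them.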